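A few compounds are considered here, and "the series" means these few. Any claim that something is new, unique, unknown or untested is made for them only; others in the source may bear on it.

Of the compounds shown here, three of a shared core have been measured in a functional assay on FM3A cells (Mus musculus) for inhibition, read by cell counting, with a stated time of 2 days; on this read-out higher numbers stand for weaker inhibition and lower numbers for stronger inhibition. Compound 1 `C=C(Br)C(=O)Nc1cccc(-c2cn3nc(-c4ccc(OC)c(OC)c4)sc3n2)c1` gives 110 nM. Compound 2 `C=C(Br)C(=O)Nc1cccc(-c2cn3nc(-c4ccc(Cl)cc4)sc3n2)c1` gives 2000 nM. Compound 3 `C=C(Br)C(=O)Nc1cccc(-c2cn3nc(-c4ccccc4)sc3n2)c1` gives 900 nM. Among these three numbers compound 3 holds the second highest place: its nearest neighbour is compound 2, reached by a 2.2-fold lower number from compound 2 to compound 3 (0.35 log units; beyond the scatter), and its furthest is compound 1, from which it is separated by an 8.2-fold higher number from compound 1 to compound 3 (0.91 log units; beyond the scatter).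

Compound 4 `C=C(Br)C(=O)Nc1cccc(-c2cn3nc(-c4ccc(F)cc4)sc3n2)c1` is not yet measured in this assay . It differs from compound 3 by fluoro in place of hydrogen on an aromatic carbon. Going by the values given here, the step that bears most directly on this change is the one between compound 2 and compound 3, where a 2.2-fold lower number from compound 2 to compound 3 (0.35 log units; beyond the scatter); in the reverse sense this means that putting chloro in place of hydrogen at the same place raised the number. Fluoro is a smaller substituent than chloro by heavy-atom count, and no fluoro compound has been measured, so the expectation rests on that single step alone. Compound 4 is therefore expected to show a number close to that of compound 3, at most modestly higher, with the estimated step of a 1.3-fold higher number from compound 3 to compound 4 (0.12 log units; within the scatter) likely near or just beyond the scatter. For compound 4 the estimate in this assay is 1200 nM, within a range from 500 nM to 3000 nM.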

Compound 4, half-maximal inhibitory concentration: 610 nM
Compound 4: middle estimate off by 2.0-fold (0.29 log units), on the high side, within the range that was stated.
By their numbers in this assay, from the lowest: compound 1; then compounds 4 and 3 (each within the scatter of the next); then compound 2.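

In this assay, fluoro in place of hydrogen on the six-membered aromatic ring of carbon only, para to a large group, gives a 1.5-fold lower number from compound 3 to compound 4 (0.17 log units; within the scatter), so at this place the fluoro and hydrogen compounds cannot be told apart. The higher number seen with chloro is therefore not shared by both halogens shown here, since fluoro in place of chloro gives a 3.3-fold lower number from compound 2 to compound 4 (0.52 log units; beyond the scatter), and compound 2 stands apart from compound 3 and compound 4 alike. The 3,4-dimethoxyphenyl group also keeps its lead over the new compound, with 4-fluorophenyl in its place giving a 5.5-fold higher number from compound 1 to compound 4 (0.74 log units; beyond the scatter), a step of the same order as the one already seen with plain phenyl.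

Nothing in the data shown explains why chloro separates from fluoro and hydrogen at this place, or why the 3,4-dimethoxyphenyl compound gives the lowest number. As far as these compounds go, it also remains open whether a single methoxy group would account for the low number of compound 1, and how an amine or a carboxylic acid at this place would read.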